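The source may hold more compounds than are shown below. What is called first, only, known or untested is meant among the compounds shown, and "the series" means these compounds.

Among the measured compounds shown here, in a functional assay on PC-3 cells (Homo sapiens) for antiproliferative activity, read by MTT assay, with a stated time of 72 h (on this read-out lower numbers stand for stronger inhibition and higher numbers for weaker inhibition), only two compounds have numbers so far. Compound 1 (`CCn1c(C(=O)NCCC(=O)OC)ccc1C(CC)(CC)c1ccc(C#CC(O)(CC)CC)c(C)c1`) gives 36300 nM and compound 2 (`CCn1c(C(=O)NCC(=O)O)ccc1C(CC)(CC)c1ccc(C#CC(O)(CC)CC)c(C)c1`) gives 2250 nM as the lower of the two. For the measured compounds named here, the one measured step is a 16-fold lower number from compound 1 to compound 2 (1.21 log units; beyond the scatter) and it is large: carboxy takes the place of (methoxycarbonyl)methyl on a saturated chain carbon bound to an amide-type nitrogen. Compound 3 (`CCn1c(C(=O)NCCCO)ccc1C(CC)(CC)c1ccc(C#CC(O)(CC)CC)c(C)c1`) is changed at that same place (2-hydroxyethyl in place of carboxy on a saturated chain carbon bound to an amide-type nitrogen) and, like compound 1, carries no carboxy. Going by the values given here, that single step is the only guide, and an imperfect one, for 2-hydroxyethyl is not the group found in compound 1. On the evidence of compound 1 at 36300 nM a higher number than that of compound 2 is expected, though a smaller rise than the measured step. The expected move is a 3.6-fold higher number from compound 2 to compound 3 (0.55 log units; beyond the scatter) and so lies beyond the scatter. Compound 3 is expected to read 8000 nM (estimated range 2500 nM to 28000 nM).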

Compound 3, half-maximal inhibitory concentration: > 50000 nM
Compound 3: a limit, no number (the forecaster's own chance of this, stated with the estimate: 10%); middle value at least 6.2-fold (0.79 log units) from the limit.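

Compound 3 gives a limit, not a number: the limit of > 50000 nM in this assay, at which 1 of the 3 values shown sits. Even so, replacing carboxy with 2-hydroxyethyl on a saturated chain carbon bound to an amide-type nitrogen gives an at least 22-fold higher number from compound 2 to compound 3 (1.34 log units; beyond the scatter), so at this place the hydroxyl-ended chain does not keep the lower number seen with carboxy. The other new step is an at least 1.3-fold higher number from compound 1 to compound 3 (0.13 log units; that floor lies within the scatter), so these two compounds cannot be put in order, and among the three compounds shown, only the one carrying carboxy has a markedly lower number.

On these data alone, whether a carboxylic acid on a longer chain would keep the number of compound 2 remains open. So does whether an amine or a primary amide at this place could do the same.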